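This account rests on a few compounds, and the source may have more. Where it says the series, first, only, none or still open, it means among the compounds named here.

Measured in an ADME assay on HaCaT cells (Homo sapiens) for antiproliferative activity, read by MTT assay, with a stated time of 48 h; a higher number here means a weaker inhibitor, a lower number a stronger inhibitor:
compound 1 `O=C(/C=C\Nc1ccc(O)cc1)c1cn(-c2ccccc2)nc1-c1ccc(F)cc1`: 16300 nM
compound 2 `COc1ccc(N/C=C\C(=O)c2cn(-c3ccccc3)nc2-c2ccc(F)cc2)cc1`: 19600 nM
compound 3 `O=C(/C=C\Nc1ccc(O)cc1)c1cn(-c2ccccc2)nc1-c1ccc(Cl)cc1`: 22600 nM

Compound 4 `COc1ccc(N/C=C\C(=O)c2cn(-c3ccccc3)nc2-c2ccc(Cl)cc2)cc1` is not yet measured. The two cores differ by chloro in place of fluoro on an aromatic carbon; that step in this assay gave a 1.4-fold higher number from compound 1 to compound 3 (0.14 log units; within the scatter). Compound 2 differs from compound 1 by methyl in place of hydrogen on an oxygen on an aromatic ring, which gave a 1.2-fold higher number from compound 1 to compound 2 (0.08 log units; within the scatter). Compound 4 differs from compound 3 by methyl in place of hydrogen on an oxygen on an aromatic ring; the place is the same in both pairs, so this is the same change carried onto the other core. Because the same change gave a 1.2-fold higher number from compound 1 to compound 2 (0.08 log units; within the scatter), a step of similar size is expected for compound 4: a 1.2-fold higher number from compound 3 to compound 4 (0.06 log units; within the scatter). This rests on a single earlier pair only. Compound 4 is thus estimated at 26000 nM, with a range from 14000 nM to 50000 nM.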

Compound 4, half-maximal inhibitory concentration: 30800 nM
Estimate against measurement, compound 4: 1.2-fold (0.07 log units) below, and the stated range covers the measured number.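

In this assay, methyl in place of hydrogen on the oxygen on an aromatic ring gives a 1.4-fold higher number from compound 3 to compound 4 (0.13 log units; within the scatter), and the size of this change holds from one core to the other: the same change on two cores in this assay, a 1.2-fold higher number (0.08 log units; within the scatter) from compound 1 to compound 2 and a 1.4-fold higher number (0.13 log units; within the scatter) from compound 3 to compound 4, 1.1-fold (0.05 log units) apart, within the scatter of two such steps

Chloro in place of fluoro on an aromatic carbon gives a 1.6-fold higher number from compound 2 to compound 4 (0.20 log units; within the scatter), and it also holds across the two cores: the same change on two cores in this assay, a 1.4-fold higher number (0.14 log units; within the scatter) from compound 1 to compound 3 and a 1.6-fold higher number (0.20 log units; within the scatter) from compound 2 to compound 4, 1.1-fold (0.05 log units) apart, within the scatter of two such steps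

Within the data shown here, all of these steps lie within the scatter, so the four compounds show only that neither change differs detectably between these two cores, not that either change truly shifts the number or that this agreement extends to other cores.

Open, from the compounds shown here alone, is whether a longer chain on that oxygen, an amine or a carboxylic acid in place of the hydroxy, or bromo in place of chloro would give a step beyond the scatter.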